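The source may report more compounds than this note shows. Statements on the series, on what has been measured and on what is new or still open speak of the compounds shown alone.

Compound 1 `COc1ccc(-c2ssc(=S)c2-c2cc(OC)c(OC)c(OC)c2)cc1[N+](=O)[O-]` and compound 2 `COc1ccc(-c2ssc(=S)c2-c2cc(OC)c(OC)c(OC)c2)cc1N` share one core, and in a functional assay on SGC-7901 cells (Homo sapiens) for antiproliferative activity, read by MTT assay, with a stated time of 72 h (a higher number here means a weaker inhibitor, a lower number a stronger inhibitor), compound 1 gives 13600 nM while compound 2 gives 444 nM. The change between them, (amino in place of nitro on an aromatic carbon), produced a step of a 31-fold lower number from compound 1 to compound 2 (1.49 log units; beyond the scatter). Compound 3 `COc1ccc(-c2ssc(=O)c2-c2cc(OC)c(OC)c(OC)c2)cc1[N+](=O)[O-]` carries the nitro group of compound 1 on a different core; the difference between the two cores is not broken down here. In this assay compound 3 gives 440 nM, a number that sits within the scatter of compound 2 and well below that of compound 1.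

Compound 4 `COc1ccc(-c2ssc(=O)c2-c2cc(OC)c(OC)c(OC)c2)cc1N` has not yet been measured. It differs from compound 3 by amino in place of nitro on an aromatic carbon, the same change that turned compound 1 into compound 2, made at the same place. From the compounds shown here alone, the step from compound 3 to compound 4 in this assay is expected to be a 4.0-fold lower number from compound 3 to compound 4 (0.60 log units; beyond the scatter), resting on the large step of a 31-fold lower number from compound 1 to compound 2 (1.49 log units; beyond the scatter) but tempered because compound 3 already gives 440 nM on a core whose response to this change is unknown. For compound 4 the estimated value is 110 nM, with a range from 20 nM to 500 nM.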

Compound 4, half-maximal inhibitory concentration: 172 nM
Estimate against measurement, compound 4: 1.6-fold (0.19 log units) below; low and high end bracket the measured number.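

In this assay, amino in place of nitro on an aromatic carbon again gave a lower number on the second core, with a 2.6-fold lower number from compound 3 to compound 4 (0.41 log units; beyond the scatter). The direction of the change thus held on both cores in this series, but its size did not carry over from one core to the other: the same change on two cores in this assay, a 31-fold lower number (1.49 log units; beyond the scatter) from compound 1 to compound 2 and a 2.6-fold lower number (0.41 log units; beyond the scatter) from compound 3 to compound 4, 12-fold (1.08 log units) apart, beyond the scatter of two such steps Two pairs do not show which feature of the cores sets this gap, and they do not predict the size of the step on any further core.

Among the compounds shown, only nitro and amino stand at this place on the ring, so it remains open how a hydroxyl group, an acetamide or a dimethylamino group would read there on either core. From the compounds shown here alone, it also remains open whether the gap between the two steps would persist if the methoxy group on the same ring were replaced by an ethoxy group.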